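A Phenyl Swap on a Fast-Cleared Compound

The compounds below may be only part of what the source reports. "The series", "measured", "known", "first", "only" and "open" are said of these compounds alone.

Measured in an ADME assay on liver for metabolic stability, with Liver microsome (Homo sapiens) as the target, read by LC-MS, using microsomes; on this read-out lower numbers stand for slow clearance and higher numbers for fast clearance:
- Compound 1 `O=C(NCc1cc(Cl)ccc1-n1cnnn1)[C@@H]1C[C@@H]2C[C@@H]2N1C(=O)[C@H](O)c1cccc(Cl)c1`: > 500 mL.min-1.g-1
- Compound 2 `CC(C)(C)[C@@H](O)C(=O)N1C[S+]([O-])C[C@H]1C(=O)NCc1cc(Cl)ccc1-n1cnnn1`: < 12 mL.min-1.g-1
- Compound 3 `O=C(NCc1cc(Cl)ccc1-n1cnnn1)[C@@H]1CC=NN1C(=O)[C@H](O)C1CCCCC1`: 63 mL.min-1.g-1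

Compound 1 gives > 500 mL.min-1.g-1, which is a limit and not a number, and it stands at the limit of > 500 mL.min-1.g-1 in this assay, at which 1 of the 3 values shown sits. Compound 2 gives < 12 mL.min-1.g-1, which is also a limit, and it stands at the limit of < 12 mL.min-1.g-1 in this assay, at which 1 of the 3 values shown sits. Among the compounds with values here, compound 3 gives 63 mL.min-1.g-1, the only exact number of the three.

Compound 4 `O=C(NCc1cc(Cl)ccc1-n1cnnn1)[C@@H]1C[C@@H]2C[C@@H]2N1C(=O)[C@H](O)c1ccccc1F` keeps the core of compound 1 and changes one group: 2-fluorophenyl in place of 3-chlorophenyl on a saturated chain carbon bound to a carbonyl carbon and an oxygen on a saturated carbon. It carries 2-fluorophenyl in place of 3-chlorophenyl on a saturated chain carbon bound to a carbonyl carbon and an oxygen on a saturated carbon. Within the data shown here, no two measured compounds differ in only one place, so the expectation rests on compound 1 alone, whose > 500 mL.min-1.g-1 is a limit. The expected step is an at least 1.5-fold lower number from compound 1 to compound 4 (0.19 log units; that floor lies within the scatter), a modest move toward slower clearance or none beyond the scatter. The estimate for compound 4 is 320 mL.min-1.g-1, with an expected range from 130 mL.min-1.g-1 to 700 mL.min-1.g-1.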

Compound 4, intrinsic clearance in microsomes: < 12 mL.min-1.g-1
Compound 4: a limit, no number; the forecaster's own chance of this, stated with the estimate: 35%; middle value at least 26-fold (1.42 log units) from the limit.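

In this assay, putting 2-fluorophenyl in place of 3-chlorophenyl on a saturated chain carbon bound to a carbonyl carbon and an oxygen on a saturated carbon gives an at least 41-fold lower number from compound 1 to compound 4 (1.61 log units; beyond the scatter), so on the core of compound 1 this one exchange is enough to carry a large change in the read-out, which no earlier comparison could show. The result for compound 4 is a limit: the limit of < 12 mL.min-1.g-1 in this assay, at which 2 of the 4 values shown sit. The result for compound 1 is also a limit: the limit of > 500 mL.min-1.g-1 in this assay, at which 1 of the 4 values shown sits.

The compounds shown leave open how much of the step goes with losing the chlorine and how much with gaining the fluorine. They also leave open how an unsubstituted phenyl or a pyridine ring would read at this place, and whether 2-fluorophenyl would give the same step on another core.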